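This account rests on a few compounds, and the source may have more. Where it says the series, first, only, none or still open, it means among the compounds named here.

Two compounds have been measured in a functional assay on MCF7 cells (Homo sapiens) for inhibition; on this read-out lower numbers stand for stronger inhibition and higher numbers for weaker inhibition:

compound 1, `N#CC1CN1C(=O)Nc1ccc([N+](=O)[O-])cc1`: 3000 nM
compound 2, `N#CC1CN1C(=O)NC1CCCCC1`: 13000 nM

Of these two numbers, compound 1 has the lower one, and the gap to compound 2 lies beyond the usual scatter of repeated measurements, so compound 1 is the stronger inhibitor of the pair in this assay. Both compounds share the same cyanoaziridine urea core and differ only in what hangs on the urea nitrogen: a nitrophenyl ring in compound 1 and a cyclohexyl ring in compound 2.

Going by the values given here, compound 3, `N#CC1CN1C(=O)Nc1ccc(C(F)(F)F)cc1`, keeps the aromatic ring of compound 1 and changes only one group on it: trifluoromethyl in place of nitro on an aromatic carbon. Among the compounds with values here, no measured pair shows the effect of this exact change, so the expectation must rest on compound 1 alone. Because compound 1 gives 3000 nM, the step from compound 1 to compound 3 is expected to be small, around or slightly above the scatter, with the number of compound 3 expected to rise modestly; the expected step is a 1.5-fold higher number from compound 1 to compound 3 (0.18 log units; within the scatter). For compound 3 in this assay a value of 4500 nM is estimated, with a range of 1500 nM to 14000 nM.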

Compound 3, half-maximal inhibitory concentration: 1500 nM
The estimate for compound 3 lay 3.0-fold (0.48 log units) above the measured number, within the range that was stated.
By their numbers in this assay, from the lowest: compounds 3 and 1 (each within the scatter of the next); then compound 2.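

Going by these compounds alone, until now, no pair of compounds isolated a single group at this place on the ring. In this assay, putting trifluoromethyl in place of nitro on an aromatic carbon gives a 2.0-fold lower number from compound 1 to compound 3 (0.30 log units; within the scatter), so this assay cannot tell the two compounds apart. At least in this one case, then, inhibition at this level does not depend on keeping the nitro group, even though the exchange replaces nitrogen and oxygen atoms with carbon and fluorine atoms and removes the hydrogen-bond acceptors counted for nitro; nothing available here explains this result.

Still open, on these data alone, is whether this tolerance extends to other groups at the same place on the ring, such as an amine, a carboxylic acid or a longer carbon chain, since one exchange cannot show how broad it is. The compounds shown also leave open how much the nitrile on the shared core contributes, which could be tested by replacing it with a group such as an amide.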